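This account rests on a few compounds, and the source may have more. Where it says the series, first, only, none or still open, it means among the compounds named here.

Notes on the series. Compound 1 `COc1cc2c(cc1OC)CN(CCC(=O)c1c(C)c(OC)c(OC)c(OC)c1O)CC2` carries a propanone-linked trimethoxy phenol on the shared core; in an assay on membranes from liver (strain Sprague-Dawley) for displacement of a labelled ligand from Sigma intracellular receptor 2 (Rattus norvegicus), read by scintillation counting, with a stated time of 120 min, in the presence of a further agent that is not named here (on this read-out lower numbers stand for stronger inhibition and higher numbers for weaker inhibition), compound 1 gives only a limit, > 1000 nM, and no number. Compound 2 `COc1ccc(C(O)CCN2CCc3cc(OC)c(OC)cc3C2)c(C)c1`, a hydroxypropyl-linked 4-methoxy-2-methylphenyl on the same core, gives 18.2 nM in this assay. Compound 3 `COc1ccc(C(O)CCCCN2CCc3cc(OC)c(OC)cc3C2)c(C)c1`, where the hydroxyalkyl linker is lengthened, gives 5.2 nM in this assay. Among the numbers shown, compound 3 stands lowest; the value of compound 2 is higher, and that gap lies beyond the usual scatter of repeated measurements.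

Compound 4 `COc1ccc(C(O)CCCCN2CCc3cc(OC)c(OC)cc3C2)c(OC)c1` is not yet measured. Relative to compound 3, the change is methoxy in place of methyl on an aromatic carbon, so that the 4-methoxy-2-methylphenyl of compound 3 becomes 2,4-dimethoxyphenyl. Among the compounds with values here, no measured pair in this set shows this exact exchange, so the expectation rests on the values of compounds 2 and 3 alone. The change from compound 3 to compound 4 is expected to be small, a 1.2-fold higher number from compound 3 to compound 4 (0.06 log units; within the scatter), within or close to the scatter, with no clear direction. For compound 4 the estimated value in this assay is 6 nM, with a range from 2 nM to 20 nM.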

Compound 4, inhibition constant: 6.2 nM
Estimate against measurement, compound 4: 1.0-fold (0.01 log units) below, within the range that was stated.
By their numbers in this assay, from the lowest: compounds 3 and 4 (each within the scatter of the next); then compound 2. At a limit, above all of these: compound 1.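

Notes on the methoxy exchange. In this assay, methoxy in place of methyl on an aromatic carbon, ortho to a large group and meta to a methoxy group, gives a 1.2-fold higher number from compound 3 to compound 4 (0.08 log units; within the scatter), so this read-out does not separate the 4-methoxy-2-methylphenyl from the 2,4-dimethoxyphenyl end of the chain. Within the data shown here, this is the first pair in the set that differs in one place, and it shows that, on the lengthened hydroxyalkyl linker, a group with one more heavy atom and one hydrogen-bond acceptor can stand at this position without a step beyond the scatter. Nothing measured in this set speaks to why the two compounds read alike.

The compounds shown leave open whether the same exchange would also stay within the scatter on the shorter hydroxypropyl linker of compound 2. They also leave open how this position would read with a different group there, such as a hydroxyl, a chlorine atom, an ethoxy group or an amine.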